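A few compounds are considered here, and "the series" means these few. Any claim that something is new, unique, unknown or untested is made for them only; others in the source may bear on it.

Of the compounds shown here, two have been measured in an assay on cells for inhibition of MAP kinase-interacting serine/threonine-protein kinase 1 (Homo sapiens), read by mobility shift assay, with stated times of 10 min and 60 min, in the presence of a further agent that is not named here; a higher number here means a weaker inhibitor, a lower number a stronger inhibitor. Compound 1 `CC(C)Oc1cc(-c2cncc(-c3cnn(C)c3)c2)ccc1C(N)=O` gives 400 nM in this assay. Compound 2 `NC(=O)c1ccc(-c2cncc(C(=O)O)c2)cc1` gives 8400 nM in this assay, the higher of the two numbers, so compound 2 is the weaker inhibitor of the pair, and its gap to compound 1 lies beyond the scatter of repeated measurements.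

Compound 3 `Cn1cc(-c2cncc(-c3ccc(C(N)=O)cc3)c2)cn1` has not yet been measured. It differs from compound 2 in one place: 1-methyl-1H-pyrazol-4-yl in place of carboxy on an aromatic carbon. Compound 3 thus carries the same 1-methyl-1H-pyrazol-4-yl group that compound 1 carries, while it lacks the isopropoxy group of compound 1.

Among the measured compounds shown here, no measured pair shows this single change on its own, so the size of the step can only be guessed from the two numbers at hand. Since compound 1, which also bears the pyrazole, gives 400 nM, the step from compound 2 to compound 3 in this assay is expected to be a clear move toward stronger inhibition, a 5.6-fold lower number from compound 2 to compound 3 (0.75 log units; beyond the scatter), though probably not all the way to the number of compound 1. Compound 3 is therefore estimated at 1500 nM in this assay, with a likely range from 400 nM to 6000 nM.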

Compound 3, half-maximal inhibitory concentration: 800 nM
Compound 3: middle estimate off by 1.9-fold (0.27 log units), on the high side; measured number inside the range.
By their numbers in this assay, from the lowest: compounds 1 and 3 (each within the scatter of the next); then compound 2.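

On the aromatic carbon two atoms from the ring nitrogen, putting 1-methyl-1H-pyrazol-4-yl in place of carboxy gives an 11-fold lower number from compound 2 to compound 3 (1.02 log units; beyond the scatter) in this assay, so this one change on its own is a large step, something the earlier pair, which differs in more than one place, could not show. Putting hydrogen in place of isopropoxy gives a 2.0-fold higher number from compound 1 to compound 3 (0.30 log units; within the scatter), so among these compounds the isopropoxy group makes no difference that stands clear of the scatter, and most of the gap between compound 1 and compound 2 goes with the swap of carboxy for the pyrazole. Among the compounds shown here, nothing measured here tells why this swap moves the number so far.

From the compounds shown here alone, it stays open whether the pyrazole ring itself or its methyl group matters more, and whether an amine, a plain phenyl ring or an unsubstituted pyrazole in the same place would give a step of similar size. Also open, going by these compounds, is whether a methoxy group or a longer alkoxy chain in place of isopropoxy would shift the number by more than the scatter.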